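Inverting Two Ring Stereocentres of Compound 2

The source may report more compounds than this note shows. Statements on the series, on what has been measured and on what is new or still open speak of the compounds shown alone.

For the measured compounds named here, in a functional assay on HCT-116 cells (Homo sapiens) for antiproliferative activity (on this read-out lower numbers stand for stronger inhibition and higher numbers for weaker inhibition), compound 2 `CC[C@H](C)[C@H]1C(=O)N[C@H](Cc2ccc(O)c(Br)c2)C(=O)N[C@@H](C(C)(C)O)C(=O)O[C@H](c2ccccc2)[C@H](C)/C=C/C=C(\C)[C@H](OC)C[C@@H]2O[C@@]2(C)C(=O)N1C` gives 1.59 nM, the lowest of the three numbers so far. Compound 1 `CC[C@H](C)[C@H]1C(=O)N[C@H](Cc2ccc(O)c(Br)c2)C(=O)N[C@@H](C(C)(C)O)C(=O)O[C@H](c2ccccc2)[C@H](C)/C=C/C=C(\C)[C@H](OC)C/C=C(\C)C(=O)N1C` gives 3.88 nM, and compound 3 `CC[C@H](C)[C@H]1C(=O)N[C@H](Cc2ccc(O)c(Br)c2)C(=O)N[C@@H](C(C)C)C(=O)O[C@H](c2ccccc2)[C@H](C)/C=C/C=C(\C)[C@H](OC)C[C@@H]2O[C@@]2(C)C(=O)N1C` gives 3.93 nM. Compound 4 `CC[C@H](C)[C@H]1C(=O)N[C@H](Cc2ccc(O)c(Br)c2)C(=O)N[C@@H](C(C)(C)O)C(=O)O[C@H](c2ccccc2)[C@H](C)/C=C/C=C(\C)[C@H](OC)C[C@H]2O[C@]2(C)C(=O)N1C` is unmeasured, and it differs from compound 2 in configuration alone: the two compounds have the same atoms and bonds and differ only in configuration as drawn: 2 of 11 stereo elements differ; a stereocentre at a saturated ring carbon is drawn S in compound 2 and R in compound 4; a stereocentre at a saturated ring carbon is drawn R in compound 2 and S in compound 4. Going by the values given here, the only measured single change, a 2.5-fold higher number from compound 2 to compound 3 (0.39 log units; beyond the scatter), replaces hydroxy with hydrogen, so it offers just a rough scale, and no measured pair tests configuration. Compound 2 already holds the lowest number, so the expected movement is upward, and a step larger than that modest one remains possible. The expected step is a 7.5-fold higher number from compound 2 to compound 4 (0.88 log units; beyond the scatter). For compound 4, the estimated value is 12 nM, within an expected range of 2.5 nM to 80 nM.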

Compound 4, half-maximal inhibitory concentration: > 200 nM
Compound 4: only a limit was reported; the forecaster's own chance of this, stated with the estimate: 3%; middle value at least 16-fold (1.22 log units) from the limit.
By their numbers in this assay, from the lowest: compound 2; then compounds 1 and 3 (each within the scatter of the next). At a limit, above all of these: compound 4.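

In this assay, inverting the two saturated ring carbons gives an at least 120-fold higher number from compound 2 to compound 4 (2.09 log units; beyond the scatter), set against a 2.5-fold higher number from compound 2 to compound 3 (0.39 log units; beyond the scatter) for replacing hydroxy with hydrogen. Compound 4 reads > 200 nM, which is a limit and not a number. This is the first evidence that configuration at these ring carbons matters, and the large step can be tied to configuration alone: the fact that compounds 2 and 4 differ only in the configuration as drawn

From the compounds shown here alone, whether inverting just one of the two stereocentres would be enough stays open. So does how an amine or a longer chain on these ring carbons would behave.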